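Adding a Ring to the Amide Side Chain

A few compounds are considered here, and "the series" means these few. Any claim that something is new, unique, unknown or untested is made for them only; others in the source may bear on it.

In a functional assay on MCF7 cells (Homo sapiens) for antiproliferative activity, read by MTT assay, with a stated time of 24 h (on this read-out higher numbers stand for weaker inhibition and lower numbers for stronger inhibition), compound 1 (`CCn1c(C(=O)NCC(=O)OC)ccc1C(CC)(CC)c1ccc(OCS(=O)(=O)c2ccccc2)c(C)c1`) gives > 50000 nM, a limit of the assay and not a number. Within the data shown here, compound 2 (`CCn1c(C(=O)NC(C)(C)CO)ccc1C(CC)(CC)c1ccc(OCS(=O)(=O)c2ccccc2)c(C)c1`) gives 20700 nM, the only true number so far. Among the measured compounds shown here, the one measured step, an at least 2.4-fold lower number from compound 1 to compound 2 (0.38 log units; beyond the scatter), came from placing 1-(hydroxymethyl)-1-methylethyl in place of (methoxycarbonyl)methyl on an amide-type nitrogen. Compound 3 (`CCn1c(C(=O)NC2(CO)CC2)ccc1C(CC)(CC)c1ccc(OCS(=O)(=O)c2ccccc2)c(C)c1`) changes that same group again: 1-(hydroxymethyl)cyclopropyl in place of 1-(hydroxymethyl)-1-methylethyl on an amide-type nitrogen. For the measured compounds named here, no measured step shows what a ring does at this place, so this assay offers only an indirect guide. The swap to compound 3 retains the hydroxymethyl part of the group that gave compound 2 its 20700 nM, so no clear shift in either direction is expected. The expected change is a 1.0-fold lower number from compound 2 to compound 3 (0.01 log units; within the scatter), which would lie within the usual scatter. Compound 3 is estimated at 20000 nM, with an expected range of 9000 nM to 45000 nM.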

Compound 3, half-maximal inhibitory concentration: 28800 nM
Beside the measured number, compound 3's estimate is 1.4-fold (0.16 log units) below it; measured number inside the range.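

In this assay, joining the two methyl groups into a ring gives a 1.4-fold higher number from compound 2 to compound 3 (0.14 log units; within the scatter). Among these compounds, on this amide-type nitrogen, then, 1-(hydroxymethyl)cyclopropyl and 1-(hydroxymethyl)-1-methylethyl cannot be told apart, something the earlier compounds, with no ring at this place, could not show. The comparison with the (methoxycarbonyl)methyl group gives an at least 1.7-fold lower number from compound 1 to compound 3 (0.23 log units; that floor lies within the scatter), so this step does not establish a real gain, and it rests on a limit of the assay rather than a true number: the limit of > 50000 nM in this assay, at which 1 of the 3 values shown sits.

The compounds shown leave open how an amine or a carboxylic acid in place of the hydroxymethyl part would read. They also leave open whether a larger carbon ring, such as cyclobutyl or cyclohexyl, would read the same as the cyclopropyl ring.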